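Lengthening the acid chain one more carbon

A few compounds are considered here, and "the series" means these few. Any claim that something is new, unique, unknown or untested is made for them only; others in the source may bear on it.

Compound 2 `O=C(O)CCCCC1=CC[C@@H]2[C@@H](/C=C/[C@@H](O)COc3ccccc3)[C@H](O)C[C@@H]2OC1`: 13 nM
Compound 1 `O=C(O)CCC1=CC[C@@H]2[C@@H](/C=C/[C@@H](O)COc3ccccc3)[C@H](O)C[C@@H]2OC1`: 2700 nM

In a functional assay on CHO cells for agonist activity at prostaglandin E2 receptor EP3 subtype (Homo sapiens), read by fluorescence and calcium flux (on this read-out higher numbers stand for an effect only at larger amounts of compound and lower numbers for an effect already at smaller amounts), compound 2 gives the lowest of the two numbers; its nearest neighbour, compound 1, gives 2700 nM in this assay. Compound 3 `O=C(O)CCCCCC1=CC[C@@H]2[C@@H](/C=C/[C@@H](O)COc3ccccc3)[C@H](O)C[C@@H]2OC1` differs from compound 2 by carboxymethyl in place of carboxy on a saturated chain carbon, four bonds along the chain from a double-bonded ring carbon. For the measured compounds named here, the one step that bears on this, a 210-fold lower number from compound 1 to compound 2 (2.32 log units; beyond the scatter), added two chain carbons and was large. Adding a single further carbon is expected to give at most a small change, a 2.3-fold higher number from compound 2 to compound 3 (0.36 log units; beyond the scatter), in this assay. Compound 3 is therefore estimated at 30 nM, within 6 nM to 150 nM.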

Compound 3, half-maximal effective concentration: 6400 nM
Compound 3: middle estimate off by 210-fold (2.33 log units), on the low side; measured number outside the range, above it.
By their numbers in this assay, from the lowest: compound 2; then compound 1; then compound 3.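

Going longer is not harmless: in this assay one added chain carbon gives a 490-fold higher number from compound 2 to compound 3 (2.69 log units; beyond the scatter) and so takes the number back up, which leaves compound 2 at the low point of these three chains. The shortest and longest chains stay fairly close, with a 2.4-fold higher number from compound 1 to compound 3 (0.37 log units; beyond the scatter) between them, so moving either way from compound 2 loses nearly all of its advantage. Still open, on these data alone, is how a chain one carbon shorter than in compound 2 would read, or an amide in place of the carboxylic acid. No evidence shown explains this sharp dependence on chain length.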